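Amide variation on the shared core: compound 4

The compounds below may be only part of what the source reports. "The series", "measured", "known", "first", "only" and "open" are said of these compounds alone.

Compound 1 `Cn1cc(-c2nn(Cc3ccc(C(=O)N4CCCCC4)cc3)c(=O)c3ccccc23)cn1` stands at 73100 nM in a functional assay on HepG2 cells (Homo sapiens) for antiproliferative activity, read by MTT assay, with a stated time of 72 h (a lower number here means a stronger inhibitor, a higher number a weaker inhibitor), the lowest of the two numbers shown, and compound 3 `Cc1noc(C)c1-c1nn(Cc2ccc(C(=O)NC3CC(C)(C)N([O])C(C)(C)C3)cc2)c(=O)c2ccccc12` at 85100 nM sits within the scatter of it. Compound 2 `Cc1noc(C)c1-c1nn(Cc2ccc(C(=O)NC3CC3)cc2)c(=O)c2ccccc12` gives only a limit in this assay, > 100000 nM. Compound 4 `Cn1cc(-c2nn(Cc3ccc(C(=O)NC4CC4)cc3)c(=O)c3ccccc23)cn1` differs from compound 1 by cyclopropylamino in place of piperidin-1-yl on a carbonyl carbon. Within the data shown here, the one measured step that bears on this, an at least 1.1-fold lower number from compound 2 to compound 3 (0.07 log units; that floor lies within the scatter), is also a change on an amide-type nitrogen and shows nothing beyond the scatter. Compound 2 sits at that limit, (the limit of > 100000 nM in this assay, at which 1 of the 3 values shown sits). For compound 4 the step of a 1.4-fold higher number from compound 1 to compound 4 (0.14 log units; within the scatter) is therefore expected to be small, if anything towards a weaker result, with a fair chance that only a limit is reported. Compound 4 is estimated at 100000 nM, with a range from 50000 nM to 200000 nM.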

Compound 4, half-maximal inhibitory concentration: > 100000 nM
Compound 4: a limit, no number; the forecaster's own chance of this, stated with the estimate: 45%; the middle value sits exactly at the limit.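

In this assay compound 4 gives > 100000 nM as a limit and not a number. Cyclopropylamino in place of piperidin-1-yl on a carbonyl carbon gives an at least 1.3-fold higher number from compound 1 to compound 4 (0.13 log units; that floor lies within the scatter) and so no change shown beyond the scatter, while the full size of the step remains unknown. The step between compound 2 and compound 4 cannot be read, and the limit now holds much of this small set: the limit of > 100000 nM in this assay, at which 2 of the 4 values shown sit.

Going by these compounds, whether morpholin-4-yl or dimethylamino in place of piperidin-1-yl would give a number clearly apart from compound 1 remains open. A carboxylic acid at this carbonyl position also remains untested in the compounds shown.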